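A few compounds are considered here, and "the series" means these few. Any claim that something is new, unique, unknown or untested is made for them only; others in the source may bear on it.

Compound 1 `C[C@@H](NC(=O)Nc1cccc(C(F)(F)F)c1)c1ccccc1` gives 70% in an ADME assay on the whole organism with Oryza sativa as the target, tested at 10 uM; on this read-out lower numbers stand for a stronger effect and higher numbers for a weaker effect at the one concentration tested. Compound 2 `CC(=O)c1cccc(NC(=O)N[C@H](C)c2ccccc2)c1`, which carries an acetyl in place of the trifluoromethyl on an aromatic carbon, gives 73% in this assay; the two numbers sit within the scatter of each other, as the step of a number 3 percentage points higher from compound 1 to compound 2 (within the scatter) shows. Compound 3 `C[C@@H](NC(=O)Nc1cccc(F)c1)c1ccccc1` differs from compound 2 at the same aromatic carbon: fluoro in place of acetyl on an aromatic carbon. Within the data shown here, the only step that bears on this change is the one from compound 1 to compound 2, and it stayed within the scatter, so no step beyond the scatter is expected in this assay. Compound 3 is therefore estimated at 72%, from 60% to 84%, an expected step of a number 1 percentage points lower from compound 2 to compound 3 (within the scatter).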

Compound 3, a percentage reported as activity, at one concentration (the size of the read-out at that concentration, not a potency): 84%
Compound 3: the middle estimate sits 12 percentage points below what was measured, within the range that was stated.
By their numbers in this assay, from the lowest: compounds 1 and 2 (each within the scatter of the next); then compound 3.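

In this assay this aromatic carbon proves sensitive to its substituent: fluoro weakens the effect at the one concentration tested, both in place of acetyl (a number 11 percentage points higher from compound 2 to compound 3 (beyond the scatter)) and in place of trifluoromethyl (a number 14 percentage points higher from compound 1 to compound 3 (beyond the scatter)). Acetyl and trifluoromethyl had stayed within the scatter of each other, so among these three compounds only fluoro stands apart. Nothing available explains this shift. As far as these compounds go, whether an amine, a carboxylic acid or a methoxy group on this carbon would behave like fluoro or like the other two remains open.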